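Methoxy to cyano on the aryl ether: lipophilicity notes

The source may report more compounds than this note shows. Statements on the series, on what has been measured and on what is new or still open speak of the compounds shown alone.

Measured in a physicochemical assay for lipophilicity, at pH 7.4; a higher number here means a more lipophilic compound, a lower number a more polar compound:
compound 1 `COc1ccccc1OCc1cc(C)nc(-c2ccccn2)n1`: 2.5
compound 2 `COc1ccc(OCc2cc(C)nc(-c3ccccn3)n2)cc1`: 2.8
compound 3 `Cc1cc(COc2ccccc2C#N)nc(-c2ccccn2)n1`: 2.7

The three values lie within the scatter of one another, so no ordering among them is claimed. The difference between the cores of compound 1 and compound 2 is not broken down here. Compound 3 is compound 1 with cyano in place of methoxy on an aromatic carbon; this gave a number 0.20 log units higher from compound 1 to compound 3 (within the scatter). Compound 4, `Cc1cc(COc2ccc(C#N)cc2)nc(-c2ccccn2)n1`, is not yet measured in this assay; it is compound 2 with cyano in place of methoxy on an aromatic carbon. Going by the values given here, the change is the same kind as the one that gave compound 3, but the place differs: ortho to a large group in compound 3, para to a large group in compound 4. Among the compounds with values here, the step is expected to be about a number 0.20 log units higher from compound 2 to compound 4 (within the scatter), resting on the single measured instance, a number 0.20 log units higher from compound 1 to compound 3 (within the scatter). Compound 4 is thus estimated at 3, between 2.7 and 3.3.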

Compound 4, distribution coefficient: 2.6
Beside the measured number, compound 4's estimate is 0.40 log units above it, and the stated range ends above it.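

In (this assay), cyano in place of methoxy on an aromatic carbon gave (a number 0.20 log units higher from compound 1 to compound 3 (within the scatter)) on the core of compound 1 and (a number 0.20 log units lower from compound 2 to compound 4 (within the scatter)) on the core of compound 2. Both steps lie within the scatter, so neither establishes a direction or size for the change that could be carried from one core to the other, and the place on the ring differs between the two pairs as well as the core. No data at hand bear on why the two steps read as they do.

Still open, from the compounds shown here alone, is whether a different replacement in the same place, such as an amine or a carboxylic acid, would give a step beyond the scatter in (this assay). Also open, going by these compounds, is whether such a step would hold on both cores.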